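The source may report more compounds than this note shows. Statements on the series, on what has been measured and on what is new or still open speak of the compounds shown alone.

Working notes on the series.

Compound 1 `Cc1ccc(-n2cc(C(=O)Nc3cc(F)cc(F)c3)c(=O)c3ccc(N(C)C)nc32)cc1OCCCCCCC[N+]12CCN(CC1)CC2` and compound 2 `CN(C)c1ccc2c(=O)c(C(=O)Nc3cc(F)cc(F)c3)cn(-c3ccc(Cl)c(OCCCCCCC[N+]45CCN(CC4)CC5)c3)c2n1` share one core, while compound 3 `CC[N+]1(CCCCCCCOc2ccc(-n3cc(C(=O)Nc4cc(F)cc(F)c4)c(=O)c4ccc(N(C)C)nc43)c(C)c2)CCCCC1` and compound 4 `CC[N+]1(CCCCCCCOc2ccc(-n3cc(C(=O)Nc4cc(F)cc(F)c4)c(=O)c4ccc(N(C)C)nc43)c(Cl)c2)CCCCC1` share another; the difference between the two cores is not broken down here. In an assay on LX2 cells for inhibition of COL1A1 promoter (Homo sapiens), read by a luciferase reporter, with a stated time of 24 h, tested at 20 uM (on this read-out higher numbers stand for a stronger effect at the one concentration tested and lower numbers for a weaker effect), compound 1 gives 5.07%. In the same assay compound 2 gives 8.08%. The change from compound 1 to compound 2 is chloro in place of methyl on an aromatic carbon and the step is a number 3 percentage points higher from compound 1 to compound 2 (within the scatter). For compound 3 this assay reports "not active" (no number reported), so no number stands for it. Compound 4 is not yet measured; it differs from compound 3 by chloro in place of methyl on an aromatic carbon. This is the same kind of change as that from compound 1 to compound 2, though the place differs: there the carbon sits para to a large group, here meta to a large group. Among the compounds with values here, the step from compound 3 to compound 4 in this assay is expected to be small, since the one measured example of this change, the step from compound 1 to compound 2 of a number 3 percentage points higher from compound 1 to compound 2 (within the scatter), lies within the scatter and compound 3 itself gave no number. Compound 4 is therefore estimated at 5%, with a range from -5% to 15%.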

Compound 4, a percentage reported as inhibition, at one concentration (the size of the read-out at that concentration, not a potency): "not active" (no number reported)
Compound 4 has no reported number here; the estimate stays without a comparison.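

In this assay, compound 3 and compound 4 are both reported without a number, so no step can be read between them. The compounds shown leave open whether chloro in place of methyl changes the read-out on the core of compound 3. No information shown bears on the cause of this result.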